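A few compounds are considered here, and "the series" means these few. Any claim that something is new, unique, unknown or untested is made for them only; others in the source may bear on it.

Working notes on the series, all read in a functional assay on HeLa cells (Homo sapiens) for cytotoxicity, read by XTT assay, with a stated time of 24 h; on this read-out lower numbers stand for stronger inhibition and higher numbers for weaker inhibition. Compound 1 (`CC(=O)Oc1cc(OC(C)=O)c2c(OC(C)=O)cc(C)c(Cl)c2c1OC(C)=O`) gives 52900 nM, compound 3 (`CC(=O)Oc1cc(OC(C)=O)c2c(OC(C)=O)c(C)cc(Cl)c2c1OC(C)=O`) gives 27900 nM, and compound 2 (`CC(=O)Oc1cc(C)c(Cl)c2c1C(=O)C=CC2=O`) gives 26200 nM. Compound 2 and compound 3 lie within the scatter of each other, so nothing separates that pair. Compound 1 has a higher number than compound 2, and that gap lies beyond the scatter. All three numbers sit in a narrow band, and no two of these compounds differ in one place only, so the series offers no measured step to size the next change.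

Compound 4 (`Cc1cc(O)c2c(c1Cl)C(=O)C=CC2=O`) is compound 2 with hydrogen in place of acetyl on an oxygen on an aromatic ring, the change from acetoxy to hydroxy: hydrogen in place of acetyl on an oxygen on an aromatic ring. Among the measured compounds shown here, with no measured precedent for this change, the expectation is tentative: a moderate move in this assay towards a lower number, that is, stronger inhibition, and one that may not clear the scatter by much. The estimated change is a 2.2-fold lower number from compound 2 to compound 4 (0.34 log units; beyond the scatter). For compound 4 the expected value is 12000 nM, with an estimated range of 4000 nM to 32000 nM.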

Compound 4, half-maximal inhibitory concentration: 13500 nM
For compound 4 the middle estimate is 1.1-fold (0.05 log units) below the measured one; measured number inside the range.
By their numbers in this assay, from the lowest: compounds 4, 2, 3 and 1 (each within the scatter of the next, the first and the last beyond it).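

The change from acetoxy to hydroxy gives the series its first measured step in this assay: a 1.9-fold lower number from compound 2 to compound 4 (0.29 log units; within the scatter). At this position, on an oxygen on an aromatic ring, the acetyl group can therefore give way to hydrogen with no change that can be told from the scatter, so the read-out does not separate compound 4 from compound 2. This is one pair on one core and sets no rule for the series, and no evidence at hand bears on why the two compounds read alike.

As far as these compounds go, what a methoxy group or a longer acyl chain such as butyryl would give on this same oxygen remains open, as does the effect of an amine in place of the hydroxy group of compound 4. Also open, from the compounds shown here alone, is whether acetoxy to hydroxy stays this small on the cores of compound 1 and compound 3, which carry acetoxy groups of their own and have no one-place partner here.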